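Removing a ring-amine protecting group in a cytotoxicity series

This account rests on a few compounds, and the source may have more. Where it says the series, first, only, none or still open, it means among the compounds named here.

Measured compounds:
compound 1 `CN1C(=S)[C@@H](NC(=O)c2nc(Cc3ccccc3)n(C3CCN(C(=O)OC(C)(C)C)C3)n2)COc2ccccc21` — > 100000 nM
compound 2 `CN1C(=S)[C@@H](NC(=O)c2nc(Cc3ccccc3)n(C3CCNC3)n2)COc2ccccc21` — > 100000 nM
compound 3 `CN1C(=S)[C@@H](NC(=O)c2nc(Cc3ccccc3)n(C3CCN(C(=O)OC(C)(C)C)CC3)n2)COc2ccccc21` — > 100000 nM

In a toxicity assay on HT-29 cells (Homo sapiens) for cytotoxicity (a higher number here means that more compound is tolerated, a lower number that less compound is tolerated), compound 1 gives > 100000 nM, which is a limit of the assay rather than a number. Compound 2 gives > 100000 nM, also a limit. Compound 3 gives > 100000 nM, again a limit. The three values share (the limit of > 100000 nM in this assay, at which 3 of the 3 values shown sit).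

Compound 2 arises from compound 1 through (hydrogen in place of tert-butoxycarbonyl on an amine nitrogen in a ring), and the resulting step is a step that the two limits leave unreadable from compound 1 to compound 2. Compound 4 `CN1C(=S)[C@@H](NC(=O)c2nc(Cc3ccccc3)n(C3CCNCC3)n2)COc2ccccc21` is the not yet measured partner of compound 3, formed through (hydrogen in place of tert-butoxycarbonyl on an amine nitrogen in a ring). The two changes are the same kind of change, not the same: in the first the ring is a five-membered non-aromatic ring with two ring bonds from the ring atom that bears a large group, in the second a six-membered non-aromatic ring with three ring bonds from that atom. How the core of compound 1 and the core of compound 3 differ is not broken down here.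

Because the earlier change gave a step that the two limits leave unreadable from compound 1 to compound 2, the step that the limit leaves unreadable from compound 3 to compound 4 is expected to leave compound 4 at the same limit. Compound 4 is estimated at 150000 nM.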

Compound 4, half-maximal cytotoxic concentration: > 100000 nM
Compound 4 was reported as a limit (the forecaster's own chance of this, stated with the estimate: 85%); the middle value lies beyond the limit too.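

In this assay compound 4 gives > 100000 nM, which is a limit of the assay and not a number. No step among compound 1, compound 2, compound 3 and compound 4 can therefore be read: the limit of > 100000 nM in this assay, at which 4 of the 4 values shown sit.

The compounds shown leave open whether exchanging tert-butoxycarbonyl for hydrogen, or pyrrolidin-3-yl for piperidin-4-yl, alters how much compound the cells tolerate.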